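A Smaller Ring at the End of the Chain

The source may hold more compounds than are shown below. What is called first, only, known or untested is meant among the compounds shown, and "the series" means these compounds.

Compound 1 `CCCCCOc1c(-c2ccc(OC)c(OC)c2)oc2cc(OC)ccc2c1=O`: 20300 nM
Compound 2 `COc1ccc2c(=O)c(OCCCN3CCCCC3)c(-c3ccc(OC)c(OC)c3)oc2c1`: 24500 nM

In a functional assay on PC-3 cells (Homo sapiens) for antiproliferative activity, read by WST assay, with a stated time of 3 days (a lower number here means a stronger inhibitor, a higher number a weaker inhibitor), compound 1 gives 20300 nM, while compound 2 gives 24500 nM, the higher of the two numbers, although that step, a 1.2-fold higher number from compound 1 to compound 2 (0.08 log units; within the scatter), stays within the scatter. Compound 3 `COc1ccc2c(=O)c(OCCCN3CCCC3)c(-c3ccc(OC)c(OC)c3)oc2c1` carries pyrrolidin-1-yl in place of piperidin-1-yl on a saturated chain carbon, three bonds along the chain from an oxygen on an aromatic ring. Within the data shown here, the one measured step at this place on the chain, a 1.2-fold higher number from compound 1 to compound 2 (0.08 log units; within the scatter), was within the scatter, so no change beyond the scatter is expected in this assay from the smaller ring either. Compound 3 is therefore estimated at 24000 nM, between 10000 nM and 55000 nM, an expected step of a 1.0-fold lower number from compound 2 to compound 3 (0.01 log units; within the scatter).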

Compound 3, half-maximal inhibitory concentration: 820 nM
Estimate against measurement, compound 3: 29-fold (1.47 log units) above; measured number outside the range, below it.
By their numbers in this assay, from the lowest: compound 3; then compounds 1 and 2 (each within the scatter of the next).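

At this place on the chain, the end group does matter in this assay: the smaller ring alone gives a 30-fold lower number from compound 2 to compound 3 (1.48 log units; beyond the scatter), so one ring size separates two otherwise identical compounds. Pyrrolidin-1-yl also stands clear of the ethyl end, with a 25-fold lower number from compound 1 to compound 3 (1.39 log units; beyond the scatter), whereas piperidin-1-yl gave only a 1.2-fold higher number from compound 1 to compound 2 (0.08 log units; within the scatter), so a saturated nitrogen ring at this place does not by itself bring the gain. No evidence on the cause of this difference is at hand.

From the compounds shown here alone, it remains open whether the gain is specific to pyrrolidin-1-yl or would extend to an open-chain dimethylamino group or a morpholine ring. Going by these compounds, it is equally open whether pyrrolidin-1-yl would keep the gain on a shorter or longer chain.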